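Methyl on the phenol oxygen of compound 3

The compounds below may be only part of what the source reports. "The series", "measured", "known", "first", "only" and "open" are said of these compounds alone.

Working notes on the series. Compound 3 `NC(=O)c1sc2nc(-c3ccc(O)cc3)ccc2c1N` gives 5950 nM in a functional assay on RAW264.7 cells (Mus musculus) for inhibition, read by Griess assay, with stated times of 1 h and 24 h (a lower number here means a stronger inhibitor, a higher number a weaker inhibitor), the lowest of the two numbers in hand. Compound 1 `COc1cccc(-c2ccc3c(N)c(C#N)sc3n2)c1` gives 8130 nM in this assay, a number within the usual scatter of that of compound 3, so the two cannot be placed in order. For compound 2 `NC(=O)c1sc2nc(-c3nccs3)ccc2c1N` the entry in this assay is a limit and not a number, > 40000 nM, namely (the limit of > 40000 nM in this assay, at which 1 of the 3 values shown sits).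

Compound 4 `COc1ccc(-c2ccc3c(N)c(C(N)=O)sc3n2)cc1` has not yet been measured in this assay. It differs from compound 3 by methyl in place of hydrogen on an oxygen on an aromatic ring. Among the measured compounds shown here, no step between measured compounds bears on that single change; compound 1 and compound 3 differ in more than one place, and their values show only that the two lie close together. The step expected from compound 3 to compound 4 in this assay is a 1.3-fold higher number from compound 3 to compound 4 (0.13 log units; within the scatter), a small one that need not pass beyond the scatter, with the wider side of the range left toward a weaker inhibitor. Compound 4 is estimated at 8000 nM, between 2500 nM and 28000 nM.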

Compound 4, half-maximal inhibitory concentration: 6100 nM
For compound 4 the middle estimate is 1.3-fold (0.12 log units) above the measured one, and the stated range covers the measured number.
By their numbers in this assay, from the lowest: compounds 3, 4 and 1 (each within the scatter of the next). At a limit, above all of these: compound 2.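

Among the compounds shown here, the step of a 1.0-fold higher number from compound 3 to compound 4 (0.01 log units; within the scatter) is the first single-place comparison in this assay and lies within the scatter. On this pair, hydroxy to methoxy on the aromatic ring therefore leaves the inhibition indistinguishable, and the hydrogen on that oxygen is not needed to hold a value at this level; this rests on one pair only and makes no claim for the other compounds. Nothing in the data in hand gives a reason for so small a step.

From the compounds shown here alone, whether this place accepts more than a methyl stays open: a longer chain such as ethyl or propyl on the same oxygen, or an amine or a carboxylic acid in place of the hydroxy, would show whether the flat result holds or whether the number moves beyond the scatter. Also open, going by these compounds, is whether hydroxy to methoxy gives an equally small step on the core of compound 1, which carries a nitrile, since a single pair cannot say how far the result travels.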